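Cytotoxicity notes: from compound 2 to compound 4

A few compounds are considered here, and "the series" means these few. Any claim that something is new, unique, unknown or untested is made for them only; others in the source may bear on it.

Of the compounds shown here, three have numbers so far in an ADME assay on MT4 cells (Homo sapiens) for cytotoxicity, read by MTT assay; on this read-out lower numbers stand for higher toxicity in this test and higher numbers for lower toxicity in this test. Compound 1 (`CC(=O)c1ccc(NC(=O)CSc2nncnc2-c2ccccc2Cl)c(Br)c1`) gives 34000 nM, and compound 3 (`O=C(CSc1nncnc1-c1ccccc1Cl)N1CCCc2ccccc21`) gives 35000 nM. Compound 2 (`Cc1ccccc1NC(=O)CSc1nncnc1-c1cccc2ccccc12`) gives 158000 nM, the highest of the three numbers, and its gaps to the other two both lie beyond the usual scatter.

Compound 4 (`Cc1ccc(NC(=O)CSc2nncnc2-c2cccc3ccccc23)c([N+](=O)[O-])c1`) has not yet been measured. It carries 4-methyl-2-nitrophenyl in place of 2-methylphenyl on an amide-type nitrogen. Going by the values given here, no pair of measured compounds differs in one place only, so the data give no direct precedent for this change and the expectation is a judgement with a wide range. Compound 2 already stands at the top of the series with 158000 nM, so a move down in this assay seems more likely than a move up. A modest downward change, slightly beyond the scatter, is expected, and the estimated size is a 2.3-fold lower number from compound 2 to compound 4 (0.35 log units; beyond the scatter). For compound 4 the estimated value is 70000 nM, with an expected range of 25000 nM to 170000 nM.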

Compound 4, half-maximal cytotoxic concentration: 147000 nM
For compound 4 the middle estimate is 2.1-fold (0.32 log units) below the measured one; the measured number falls inside the stated range.
By their numbers in this assay, from the lowest: compounds 1 and 3 (each within the scatter of the next); then compounds 4 and 2 (each within the scatter of the next).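

In this assay, the series now has its first comparison of compounds that differ in one place, and it reads a 1.1-fold lower number from compound 2 to compound 4 (0.03 log units; within the scatter), for 4-methyl-2-nitrophenyl in place of 2-methylphenyl on an amide-type nitrogen. The entering group carries more heavy atoms and brings hydrogen-bond acceptors that the leaving group lacks, yet the read-out does not move beyond the scatter, so this one change on this nitrogen leaves the number at the high end of the series. Nothing measured here speaks to the reason for this result.

Still open, from the compounds shown here alone, is whether other groups on this amide-type nitrogen, such as an aminophenyl or a phenyl bearing a carboxylic acid, would leave the number in the same place, and whether the nitro or the methyl of the entering group would read the same on its own. Also open, going by these compounds, is whether the same exchange would give a similar step on the core of compound 1, whose number lies well apart from that of compound 2.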